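The source may report more compounds than this note shows. Statements on the series, on what has been measured and on what is new or still open speak of the compounds shown alone.

Compound 3 `CCN(CC)C(=O)CC1CCc2cc(OC)c(OC)cc21` gives 27.4% in a functional assay on the whole organism (strain Swiss albino) for inhibition, with Mus musculus as the target, in the writhing test, with stated times of 60 min and 15 min, at a dose of 100 mg/kg by the oral route; on this read-out lower numbers stand for less inhibition and higher numbers for more inhibition at the one dose given (going by the name of the read-out); it stands second highest of the three numbers, nearest compound 2 `CNC(=O)CC1CCc2cc(OC)c(OC)cc21`, which gives 21.2%, and furthest from compound 1 `COc1cc2c(cc1OC)C(CC(=O)O)CC2`, which gives 44%. Against compound 1 the steps of a number 22.8 percentage points lower from compound 1 to compound 2 (beyond the scatter) and a number 16.6 percentage points lower from compound 1 to compound 3 (beyond the scatter) are both modest. Compound 4 `COc1cc2c(cc1OC)C(CC(=O)NC(C)C)CC2` differs from compound 3 by isopropylamino in place of diethylamino on a carbonyl carbon. Within the data shown here, the one measured step that bears on this, an exchange of one amine for another on a carbonyl carbon, is a number 6.2 percentage points higher from compound 2 to compound 3 (within the scatter), so no exchange of that kind has yet moved the number past the scatter. The step of a number 1.4 percentage points lower from compound 3 to compound 4 (within the scatter) is therefore expected to stay within the scatter. Compound 4 is estimated at 26%, with a range from 14% to 38%.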

Compound 4, a percentage reported as inhibition, in the whole organism at one dose (the size of the read-out at that dose, not a potency): 29.3%
For compound 4 the middle estimate is 3.3 percentage points below the measured one; the measured number falls inside the stated range.
By their numbers in this assay, from the lowest: compounds 2, 3 and 4 (each within the scatter of the next); then compound 1.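

On the carbonyl carbon, isopropylamino brings a hydrogen-bond donor where diethylamino has none, yet the result is a number 1.9 percentage points higher from compound 3 to compound 4 (within the scatter); isopropyl in place of methyl on the amide-type nitrogen gives a number 8.1 percentage points higher from compound 2 to compound 4 (within the scatter), so the three amides cannot be told apart. A third amine now also falls short of the hydroxy of the parent acid, with a number 14.7 percentage points lower from compound 1 to compound 4 (beyond the scatter). Nothing available explains either the grouping of the amides or their gap to the acid.

Still open, on these data alone, is whether a ring amine such as morpholine or the unsubstituted amide would leave this grouping. Also open, as far as these compounds go, is how a longer chain on the amide-type nitrogen would read.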